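This account rests on a few compounds, and the source may have more. Where it says the series, first, only, none or still open, it means among the compounds named here.

For the measured compounds named here, compound 2 `CS(=O)(=O)c1cnc(O[C@H]2CC[C@H](OC3CCN(C(=O)Oc4ccccc4)CC3)CC2)cn1` gives 104% in a functional assay on isolated protein for agonist activity at Glucose-dependent insulinotropic receptor (Rattus norvegicus), read by HTRF and cAMP accumulation (on this read-out higher numbers stand for larger maximal responses and lower numbers for smaller maximal responses), the lowest of the two numbers so far; compound 1 `C[C@@H](CF)OC(=O)N1CCC(O[C@H]2CC[C@H](Oc3cnc(S(C)(=O)=O)cn3)CC2)CC1` gives 123%, and the step of a number 19 percentage points lower from compound 1 to compound 2 (beyond the scatter) is modest but beyond the scatter. Compound 3 `CC(C)c1noc(CN2CCC(O[C@H]3CC[C@H](Oc4cnc(S(C)(=O)=O)cn4)CC3)CC2)n1` differs from compound 2 by (3-isopropyl-1,2,4-oxadiazol-5-yl)methyl in place of phenoxycarbonyl on an amine nitrogen in a ring. Going by the values given here, the only measured step exchanges a group on the oxygen of the carbamate, whereas this change removes the phenoxycarbonyl altogether, so no measured step bears on it directly. Both measured maximal responses are near or above the control, so for compound 3 a number in that region is expected, with a step of a number 4 percentage points higher from compound 2 to compound 3 (within the scatter). Compound 3 is estimated at 108%, between 80% and 135%.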

Compound 3, largest response reached (Emax), in percent of the reference or control that the assay uses: 115%
Compound 3: middle estimate off by 7 percentage points, on the low side; low and high end bracket the measured number.
By their numbers in this assay, from the lowest: compound 2; then compounds 3 and 1 (each within the scatter of the next).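

In this assay, the response on the amine nitrogen in a ring does not depend on a carbonyl group there: (3-isopropyl-1,2,4-oxadiazol-5-yl)methyl gives a number 11 percentage points higher from compound 2 to compound 3 (beyond the scatter). Against the 1-(fluoromethyl)ethyl carbamate, the same group gives a number 8 percentage points lower from compound 1 to compound 3 (within the scatter), so a five-membered aromatic ring with 3 hetero atoms is tolerated on this nitrogen. Nothing on hand offers a reason for either step. Open, on these data alone, is whether a benzyl group, or a pyrimidine bonded directly to this nitrogen, holds the response, and whether the isopropyl on the oxadiazole matters compared with a cyclopropyl or tert-butyl group.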